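The source may hold more compounds than are shown below. What is called first, only, known or untested is meant among the compounds shown, and "the series" means these compounds.

In a functional assay on Bel-7402 cells (Homo sapiens) for cytotoxicity, read by MTT assay (a lower number here means a stronger inhibitor, a higher number a weaker inhibitor), compound 1 `CCn1cc(C(=O)Nc2ccccc2)c(=O)c2cc(F)c(N3CCNC(C)C3)c(F)c21` gives 6000 nM. Compound 2 `CCn1cc(C(=O)Nc2ccccc2O)c(=O)c2cc(F)c(N3CCNC(C)C3)c(F)c21` reads > 50000 nM, which is a limit of the assay and not a number. Among the measured compounds shown here, compound 3 `CCn1cc(C(=O)Nc2cccc([N+](=O)[O-])c2)c(=O)c2cc(F)c(N3CCNC(C)C3)c(F)c21` gives 1000 nM, the lowest of the numbers so far, and its nearest neighbour is compound 1, reached by a 6.0-fold lower number from compound 1 to compound 3 (0.78 log units; beyond the scatter).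

Compound 4 `CCn1cc(C(=O)Nc2ccc(C(C)=O)cc2)c(=O)c2cc(F)c(N3CCNC(C)C3)c(F)c21` differs from compound 3 in one place: 4-acetylphenyl in place of 3-nitrophenyl on an amide-type nitrogen. In short, 4-acetylphenyl stands in place of 3-nitrophenyl on an amide-type nitrogen. For the measured compounds named here, no measured step makes this exchange, so the evidence is indirect. The steps of an at least 8.3-fold higher number from compound 1 to compound 2 (0.92 log units; beyond the scatter) and an at least 50-fold lower number from compound 2 to compound 3 (1.69 log units; beyond the scatter) show that changes to this group can move the number a long way in either direction. The most relevant step is a 6.0-fold lower number from compound 1 to compound 3 (0.78 log units; beyond the scatter), where nitro replaces hydrogen. Compound 4 has no nitro. Compound 4 is therefore expected to give back part of that gain, while the contribution of the acetyl remains unmeasured. A modest rise is expected in this assay, and the expected step is a 2.5-fold higher number from compound 3 to compound 4 (0.40 log units; beyond the scatter). For compound 4 the estimated value is 2500 nM, with an expected range of 600 nM to 12000 nM.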

Compound 4, half-maximal inhibitory concentration: > 50000 nM
Compound 4: only a limit was reported; the forecaster's own chance of this, stated with the estimate: 10%; middle value at least 20-fold (1.30 log units) away from the limit.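

In this assay, 4-acetylphenyl in place of 3-nitrophenyl on the amide-type nitrogen gives an at least 50-fold higher number from compound 3 to compound 4 (1.69 log units; beyond the scatter), which shows that the low number of compound 3 does not carry over to any other group of the same size on this nitrogen, even though both groups have 9 heavy atoms and one carbon-only aromatic ring. Set against the plain phenyl, the acetyl gives an at least 8.3-fold higher number from compound 1 to compound 4 (0.92 log units; beyond the scatter), so among the compounds shown two of the three substituted phenyl groups move the number up and only compound 3 goes against that. Compound 4 reads as a limit of the assay and not a number, and its step against compound 2 cannot be read, the two sharing the same limit: the limit of > 50000 nM in this assay, at which 2 of the 4 values shown sit.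

The compounds shown leave open whether the loss belongs to the acetyl itself or to where it sits on the phenyl ring, since nitro and acetyl are never compared at one ring place. They also leave open how an amine, a carboxylic acid or a methoxy group on that ring would read, so it remains unclear how narrow the gain of compound 3 over compound 1 is.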